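Cytotoxicity of a piperidine amide series on prostate cancer cells

The compounds below may be only part of what the source reports. "The series", "measured", "known", "first", "only" and "open" are said of these compounds alone.

The measurements come from an ADME assay on PC-3 cells (Homo sapiens) for cytotoxicity, read by WST assay, tested at 100 uM; a higher number here means more inhibition at the concentration tested (going by the name of the read-out), a lower number less inhibition. Compound 1 `O=C(Nc1cccc(OCCc2ccccn2)c1)C1CCCN(C(=O)c2cc(C(F)(F)F)cc(C(F)(F)F)c2)C1` gives 5% in this assay. Compound 2 `O=C(Nc1cccc(Oc2ccccc2)c1)C1CCCN(C(=O)c2cc(C(F)(F)F)cc(C(F)(F)F)c2)C1`, which differs from it only at the oxygen on an aromatic ring, gives 1% there. Going by the values given here, the one measured step, a number 4 percentage points lower from compound 1 to compound 2 (within the scatter), shows that the two numbers lie within the scatter of each other, so neither compound can be called more or less cytotoxic than the other on this evidence; both sit near the bottom of the scale. Compound 3 `O=C(Nc1cccc(Oc2nccc(C(F)(F)F)c2Cl)c1)C1CCCN(C(=O)c2cc(C(F)(F)F)cc(C(F)(F)F)c2)C1` has not been measured. It differs from compound 2 by 3-chloro-4-(trifluoromethyl)pyridin-2-yl in place of phenyl on an oxygen on an aromatic ring. Among the compounds with values here, the only step that bears on this change is the one at the same place, from compound 1 to compound 2, and that step stayed within the scatter. On that basis no step beyond the scatter is expected in this assay for compound 3, and the expected change is a number 3 percentage points higher from compound 2 to compound 3 (within the scatter). Compound 3 is estimated to give 4% in this assay, with a range from -8% to 18%.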

Compound 3, a percentage reported as inhibition, at one concentration (the size of the read-out at that concentration, not a potency): 0%
For compound 3 the middle estimate is 4 percentage points above the measured one; low and high end bracket the measured number.
By their numbers in this assay, from the lowest: compounds 3, 2 and 1 (each within the scatter of the next).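

In this assay, placing 3-chloro-4-(trifluoromethyl)pyridin-2-yl on the oxygen instead of phenyl gives a number 1 percentage points lower from compound 2 to compound 3 (within the scatter). This adds a new kind of group to the comparison: an aromatic ring with a hetero atom and a hydrogen-bond acceptor, carrying both chlorine and fluorine, attached directly to the oxygen. Set against the 2-(pyridin-2-yl)ethyl group, the same group gives a number 5 percentage points lower from compound 1 to compound 3 (within the scatter), so all three groups at this place now lie within the scatter of one another, and this heavily substituted ring does not separate itself from the simpler phenyl or from the chain-linked pyridine in this cell assay. Nothing available explains why the numbers stay together.

Going by these compounds, whether an amine or a carboxylic acid on this oxygen would give a number beyond the scatter remains open. So does whether a change elsewhere on the shared core, such as replacing the trifluoromethyl groups on the benzoyl ring with methoxy groups, would do so.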